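Benzyl thioether variation in the sulfonyl amidine series

A few compounds are considered here, and "the series" means these few. Any claim that something is new, unique, unknown or untested is made for them only; others in the source may bear on it.

For the measured compounds named here, compound 2 `Cc1cccc(CSc2cc(Cl)c(C)cc2S(=O)(=O)/N=C(\N)n2nc(C)cc2-c2ccccc2)c1` holds the higher of the two numbers measured so far. In a functional assay on HeLa cells (Homo sapiens) for cytotoxicity, read by MTT assay, with a stated time of 72 h (a higher number here means a weaker inhibitor, a lower number a stronger inhibitor), compound 2 gives 155000 nM, while compound 1 `Cc1cc(-c2ccccc2)n(/C(N)=N/S(=O)(=O)c2cc(C)c(Cl)cc2SCc2cccc3ccccc23)n1` gives 3000 nM. Going by the values given here, the only measured step, a 52-fold higher number from compound 1 to compound 2 (1.71 log units; beyond the scatter), exchanges naphthalen-1-yl for 3-methylphenyl on the saturated chain carbon bound to a sulfur.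

Compound 3 `Cc1cc(-c2ccccc2)n(/C(N)=N/S(=O)(=O)c2cc(C)c(Cl)cc2SCc2cccc(Cl)c2)n1` differs from compound 2 by chloro in place of methyl on an aromatic carbon, read one bond further out as 3-methylbenzyl to 3-chlorobenzyl. Among the compounds with values here, no measured step alters a substituent on this six-membered ring; the naphthalen-1-yl step concerns a different part of the same group and gives no guide to the size or direction here. With nothing bearing on it, the expected change in this assay is none beyond the scatter. Compound 3 is estimated at 110000 nM, within 35000 nM to 350000 nM. The expected step is a 1.4-fold lower number from compound 2 to compound 3 (0.15 log units; within the scatter).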

Compound 3, half-maximal inhibitory concentration: 8000 nM
The estimate for compound 3 lay 14-fold (1.14 log units) above the measured number; the measured number lies below the stated range.
By their numbers in this assay, from the lowest: compound 1; then compound 3; then compound 2.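

In this assay the substituent on this six-membered ring proves far from neutral: chloro in place of methyl gives a 19-fold lower number from compound 2 to compound 3 (1.29 log units; beyond the scatter), so an exchange at this one place accounts for a large share of the spread among the three compounds. With 3-chlorophenyl in place of naphthalen-1-yl, the step is only a 2.7-fold higher number from compound 1 to compound 3 (0.43 log units; beyond the scatter), so leaving naphthalen-1-yl need not cost as much as the step to compound 2 first suggested. Nothing measured bears on the reason for the gap between chloro and methyl.

On these data alone, whether fluoro, methoxy, trifluoromethyl or an amine at this place would read closer to chloro or to methyl remains open. So does whether chloro on another carbon of the same ring would give a similar number.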